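Adding a second chloro group on a new core

The source may hold more compounds than are shown below. What is called first, only, known or untested is meant among the compounds shown, and "the series" means these compounds.

Measured so far:
Compound 1 `O=C(Nc1ccccc1Cl)N1CCN(c2nccc(NCc3ccccc3)n2)CC1` gives 1590 nM in a functional assay on MDA-MB-231 cells (Homo sapiens) for antiproliferative activity, read by MTT assay, with a stated time of 24 h; on this read-out higher numbers stand for weaker inhibition and lower numbers for stronger inhibition.
Compound 2 `O=C(Nc1ccc(Cl)cc1Cl)N1CCN(c2nccc(NCc3ccccc3)n2)CC1` gives 9790 nM in this assay.
Compound 3 `COc1cccc(Nc2cc(N3CCN(C(=O)Nc4ccccc4Cl)CC3)ncn2)c1` gives 2800 nM in this assay.

Compound 1 and compound 3 differ in their cores; that difference is not broken down here. From compound 1 to compound 2 one change was made, (chloro in place of hydrogen on an aromatic carbon), and it gave a 6.2-fold higher number from compound 1 to compound 2 (0.79 log units; beyond the scatter). Compound 4 `COc1cccc(Nc2cc(N3CCN(C(=O)Nc4ccc(Cl)cc4Cl)CC3)ncn2)c1` is not yet measured; it carries the same change on the core of compound 3, namely (chloro in place of hydrogen on an aromatic carbon). Because the earlier step was a 6.2-fold higher number from compound 1 to compound 2 (0.79 log units; beyond the scatter), a step of similar size is expected here, namely a 5.4-fold higher number from compound 3 to compound 4 (0.73 log units; beyond the scatter), although a single precedent is a thin basis. Compound 4 is therefore expected to give about 15000 nM in this assay, plausibly between 5000 nM and 45000 nM.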

Compound 4, half-maximal inhibitory concentration: 7230 nM
Compound 4: middle estimate off by 2.1-fold (0.32 log units), on the high side; low and high end bracket the measured number.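

In this assay, going from 2-chlorophenyl to 2,4-dichlorophenyl on the second core again weakens inhibition, with a 2.6-fold higher number from compound 3 to compound 4 (0.41 log units; beyond the scatter). The two steps point the same way, and the difference in their size does not stand out from the usual variation between repeated measurements: the same change on two cores in this assay, a 6.2-fold higher number (0.79 log units; beyond the scatter) from compound 1 to compound 2 and a 2.6-fold higher number (0.41 log units; beyond the scatter) from compound 3 to compound 4, 2.4-fold (0.38 log units) apart, within the scatter of two such steps

So on these two cores the change carries over in direction, and no difference between the cores can be claimed. Two cores are a small sample, however, and these results show neither why the added chloro group weakens inhibition nor whether it would do so on a third core.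

As far as these compounds go, it remains open how a fluoro group, a methyl group or an amine would compare with the chloro group at this place. Whether any such group would keep or improve inhibition on either core is also unknown.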